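Swapping an Amide Side Chain for Isopropyl in Two Series

The source may report more compounds than this note shows. Statements on the series, on what has been measured and on what is new or still open speak of the compounds shown alone.

Two measured compounds share one core and differ in a single side chain. Compound 1, `NC(=O)C[C@H](NC(=O)CN(c1nc(Cl)nc2[nH]cnc12)C1CC1)C(=O)O`, carries a carbamoylmethyl group, and compound 2, `CC(C)[C@H](NC(=O)CN(c1nc(Cl)nc2[nH]cnc12)C1CC1)C(=O)O`, carries isopropyl in its place. In a functional assay on the whole organism (Tail, strain ICR) with Mus musculus as the target, in the tail flick test, with a stated time of 120 min, at a dose of 25 umol/kg by the oral route (on this read-out lower numbers stand for a weaker effect and higher numbers for a stronger effect at the one dose given), compound 1 gives 17%, and compound 2 gives 17.1%. The change itself is isopropyl in place of carbamoylmethyl on a saturated chain carbon bound to an amide-type nitrogen and a carbonyl carbon, and its step is a number 0.1 percentage points higher from compound 1 to compound 2 (within the scatter).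

Compound 3, `NC(=O)CC[C@H](NC(=O)CN(c1nc(Cl)nc2[nH]cnc12)C1CC1)C(=O)OCc1ccccc1`, has a different core; how that core differs from the core of compound 1 is not broken down here. In this assay compound 3 gives 36%, the highest of the three numbers, and its distances to compound 2 and to compound 1 lie beyond the scatter.

Compound 4, `CC(C)C[C@H](NC(=O)CN(c1nc(Cl)nc2[nH]cnc12)C1CC1)C(=O)OCc1ccccc1`, has not been measured. It differs from compound 3 by isopropyl in place of carbamoylmethyl on a saturated chain carbon, two bonds along the chain from an amide-type nitrogen and a carbonyl carbon. For the measured compounds named here, this is the same kind of change as the one from compound 1 to compound 2, but not the same: in the first pair the place is on a saturated chain carbon bound to an amide-type nitrogen and a carbonyl carbon, while here it is on a saturated chain carbon, two bonds along the chain from an amide-type nitrogen and a carbonyl carbon.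

Going by the values given here, the only comparable step, a number 0.1 percentage points higher from compound 1 to compound 2 (within the scatter), lay within the scatter, so the step from compound 3 to compound 4 is expected to be small as well, about no change at the digits printed from compound 3 to compound 4 (within the scatter). Compound 4 is therefore estimated at 36%, with a likely range from 20% to 52%, resting on compound 3 giving 36% and on the flat step seen from compound 1 to compound 2.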

Compound 4, a percentage reported as activity, at one dose (the size of the read-out at that dose, not a potency): 8.58%
Compound 4: middle estimate off by 27.4 percentage points, on the high side; measured number outside the range, below it.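

On the core of compound 3, replacing carbamoylmethyl with isopropyl at this place has a clear effect in this assay, with a number 27.4 percentage points lower from compound 3 to compound 4 (beyond the scatter). For the compounds shown here, the closest earlier swap, on the core of compound 1, gave no step that stands out from the scatter, so the flat result from that pair did not carry over, and the two steps differ clearly: the same change on two cores in this assay, a number 0.1 percentage points higher (within the scatter) from compound 1 to compound 2 and a number 27.4 percentage points lower (beyond the scatter) from compound 3 to compound 4, 27.5 percentage points apart, beyond the scatter of two such steps. This shows that one flat step is a poor guide to the next core in this series, but it does not show what produces the gap, since the two pairs differ both in their core and in where the swap sits, and two pairs alone cannot separate those two differences or reveal a general rule.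

Still open, from the compounds shown here alone, is how isobutyl would read on the core of compound 1, a comparison that would help separate the place of the change from the core around it. Also open, going by these compounds, is whether an amine or a longer chain in place of the 2-carbamoylethyl group would give a number closer to that of compound 3 or to that of compound 4.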